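From compound 3 to compound 4: an aryl ether swap

A few compounds are considered here, and "the series" means these few. Any claim that something is new, unique, unknown or untested is made for them only; others in the source may bear on it.

In a functional assay for agonist activity at Free fatty acid receptor 1 (Homo sapiens), read by FLIPR, in the presence of a further agent that is not named here (a lower number here means that less compound is needed, a higher number that more compound is needed for the effect), compound 1 `O=C1NC(=O)C(Cc2ccc(Oc3cccc(Cl)c3)cc2)S1` gives 318 nM and compound 2 `Cc1cccc(Oc2ccc(CC3SC(=O)NC3=O)cc2)c1C` gives 334 nM. Compound 3 `Cc1cccnc1Oc1ccc(CC2SC(=O)NC2=O)cc1` stands highest of the three in this assay, with 1090 nM; its gap to both other compounds lies beyond the scatter. Going by the values given here, the one measured step that reaches it, a 3.4-fold higher number from compound 1 to compound 3 (0.53 log units; beyond the scatter), raised the number upon exchanging a phenyl ether for a pyridyl ether. Compound 4 `Cc1cccc(Oc2ccc(CC3SC(=O)NC3=O)cc2)c1` differs from compound 3 by 3-methylphenyl in place of 3-methylpyridin-2-yl on an oxygen on an aromatic ring, which reverses that exchange. Because compound 1 gives 318 nM and compound 2 gives 334 nM, a downward step beyond the scatter is expected, a 3.3-fold lower number from compound 3 to compound 4 (0.52 log units; beyond the scatter). Compound 4 is therefore expected to give about 330 nM in this assay, between 150 nM and 750 nM.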

Compound 4, half-maximal effective concentration: 203 nM
Compound 4: the middle estimate sits 1.6-fold (0.21 log units) above what was measured, and the stated range covers the measured number.
By their numbers in this assay, from the lowest: compounds 4, 1 and 2 (each within the scatter of the next); then compound 3.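

In this assay, the change from a ring with one hetero atom to a ring of carbon only, with the methyl kept, gives a 5.4-fold lower number from compound 3 to compound 4 (0.73 log units; beyond the scatter). By contrast, hydrogen in place of methyl gives a 1.6-fold lower number from compound 2 to compound 4 (0.22 log units; within the scatter), and methyl in place of chloro gives a 1.6-fold lower number from compound 1 to compound 4 (0.19 log units; within the scatter), so neither swap separates these compounds. No supporting evidence accounts for the effect of the ring change.

As far as these compounds go, it remains open how the ring nitrogen would behave with chloro in place of the methyl. The compounds shown also leave open what an amine or a carboxylic acid on this ring would do.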